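The source may hold more compounds than are shown below. What is called first, only, known or untested is meant among the compounds shown, and "the series" means these compounds.

Values in a functional assay on HT-29 cells (Homo sapiens) for inhibition, with a stated time of 72 h (on this read-out higher numbers stand for weaker inhibition and lower numbers for stronger inhibition), are as follows
- compound 1 `COc1ccc(S(=O)(=O)N2CCc3cccc(-c4ccc(N)cc4)c32)cc1` gives 301 nM
- compound 2 `COc1ccc(S(=O)(=O)N2CCc3cccc(-c4ccc([N+](=O)[O-])cc4)c32)cc1` gives 51.8 nM
- compound 3 `COc1ccc(S(=O)(=O)N2CCc3cccc(-c4cccnc4)c32)cc1` gives 76.3 nM

Compound 3 is not separated from compound 2 (a 1.5-fold higher number from compound 2 to compound 3 (0.17 log units; within the scatter)) and lies clearly lower than compound 1 (a 3.9-fold lower number from compound 1 to compound 3 (0.60 log units; beyond the scatter)). Compound 4 `COc1ccc(S(=O)(=O)N2CCc3cccc(-c4ccc(O)cc4)c32)cc1` carries 4-hydroxyphenyl in place of pyridin-3-yl on an aromatic carbon. The closest measured groups are the substituted phenyls of compound 1 and compound 2, whose values differ beyond the scatter (a 5.8-fold lower number from compound 1 to compound 2 (0.76 log units; beyond the scatter)). For the measured compounds named here, no hydroxyl analogue has been measured, so compound 4 could fall anywhere in that span. A small upward step in this assay is expected, possibly none beyond the scatter (expected a 1.6-fold higher number from compound 3 to compound 4 (0.20 log units; within the scatter)). The estimate for compound 4 is 120 nM (expected range 40 nM to 350 nM).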

Compound 4, half-maximal inhibitory concentration: 133 nM
Compound 4: middle estimate off by 1.1-fold (0.04 log units), on the low side; low and high end bracket the measured number.
By their numbers in this assay, from the lowest: compounds 2, 3 and 4 (each within the scatter of the next, the first and the last beyond it); then compound 1.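

In this assay, the 4-hydroxyphenyl group at this aromatic carbon is not separated from pyridin-3-yl (a 1.7-fold higher number from compound 3 to compound 4 (0.24 log units; within the scatter)). On the phenyl ring, hydroxy is separated from both earlier substituents, nitro (a 2.6-fold higher number from compound 2 to compound 4 (0.41 log units; beyond the scatter)) and amino (a 2.3-fold lower number from compound 1 to compound 4 (0.35 log units; beyond the scatter)), so the three give distinct levels: nitro lowest, hydroxy intermediate, amino highest. No measured evidence bears on the reason for this order. Still open, on these data alone, is where a carboxylic acid or a nitrile in the same place on the phenyl ring would fall relative to these three levels.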